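The source may hold more compounds than are shown below. What is called first, only, known or untested is meant among the compounds shown, and "the series" means these compounds.

Working notes on the series. Compound 1 `c1ccc2c(c1)CN[C@@H](CN(CC1CCNCC1)[C@H]1CCCc3cccnc31)C2` gives 65% in an ADME assay on microsomes from liver (Rattus norvegicus) for metabolic stability, read by LC-MS, with a stated time of 10 min, tested at 0.5 uM; a lower number here means that less of the compound is left, a higher number that more of the compound is left. Among the compounds with values here, of the two compounds measured so far it holds the higher number; compound 2 `c1cnc2c(c1)CCC[C@@H]2N(CCCN1CCNCC1)Cc1nc2ccccc2[nH]1` gives 29%, a gap that lies beyond the usual scatter. No difference between compound 1 and compound 2 has been worked out, so their two values are all that can be read from that pair.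

Compound 3 `c1ccc2c(c1)CN[C@@H](CN(CC[C@H]1CCCNC1)[C@H]1CCCc3cccnc31)C2` is not yet measured and differs from compound 1 in one place: (piperidin-3-yl)methyl in place of piperidin-4-yl on a saturated chain carbon bound to an amine nitrogen. Within the data shown here, no comparable step between measured compounds is available for this change. Given only the value of compound 1 at 65%, a small downward shift in this assay is expected, at the edge of the scatter rather than clearly beyond it. Compound 3 is expected to give 55%, with a likely range from 35% to 75%. The step from compound 1 to compound 3 is thus estimated at a number 10 percentage points lower from compound 1 to compound 3 (within the scatter).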

Compound 3, percent of the compound remaining: 55%
Compound 3: middle estimate and measured number agree at the digits printed; the range from low to high includes it.
By their numbers in this assay, from the lowest: compound 2; then compounds 3 and 1 (each within the scatter of the next).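

The series now has a first readable step: a number 10 percentage points lower from compound 1 to compound 3 (within the scatter) in this assay for (piperidin-3-yl)methyl in place of piperidin-4-yl on a saturated chain carbon bound to an amine nitrogen. For this one pair, the place takes an entering group with a defined stereocentre and the same kind of six-membered non-aromatic ring without a shift beyond the usual scatter, and nothing wider can be claimed from a single step. Nothing at hand bears on what lies behind this step.

Still open, from the compounds shown here alone, is whether a group of another kind at this place, such as a carboxylic acid, an open-chain amine or a longer chain, would move the number beyond the scatter. Also open, going by these compounds, is whether the opposite stereocentre in the (piperidin-3-yl)methyl group would read the same.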